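This account rests on a few compounds, and the source may have more. Where it says the series, first, only, none or still open, it means among the compounds named here.

Compound 2 `COc1cc(NC(C)CCCNC(=O)NNC(=O)Nc2cccc(F)c2)c2ncccc2c1` and compound 1 `COc1cc(NC(C)CCCNC(=O)NNC(=O)Nc2ccc(Cl)cc2)c2ncccc2c1` share a core and differ only in the group carried on an amide-type nitrogen. In a functional assay on CCRF-CEM cells (Homo sapiens) for inhibition, read by MTT assay, with a stated time of 72 h (on this read-out higher numbers stand for weaker inhibition and lower numbers for stronger inhibition), compound 1 gives 108000 nM, and compound 2 gives 98000 nM; the two lie within the scatter of each other, as the step of a 1.1-fold lower number from compound 1 to compound 2 (0.04 log units; within the scatter) shows. Compound 3 `COc1cc(NC(C)CCCNC(=O)Nc2ccc(O)cc2)c2ncccc2c1` differs from compound 2 by 4-hydroxyphenyl in place of ((3-fluorophenyl)carbamoyl)amino on an amide-type nitrogen. The single measured step concerns a different change, so nothing shown bears directly on this one, and the expected step is a 1.1-fold lower number from compound 2 to compound 3 (0.04 log units; within the scatter), within the scatter. Compound 3 is therefore estimated at 90000 nM, with a range from 30000 nM to 300000 nM.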

Compound 3, half-maximal inhibitory concentration: 23000 nM
Beside the measured number, compound 3's estimate is 3.9-fold (0.59 log units) above it, outside the stated range (below it).
By their numbers in this assay, from the lowest: compound 3; then compounds 2 and 1 (each within the scatter of the next).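

Replacing the whole group on the amide-type nitrogen matters more here than the earlier change of ring substituent, which stayed within the scatter: this assay shows a 4.3-fold lower number from compound 2 to compound 3 (0.63 log units; beyond the scatter) for 4-hydroxyphenyl in place of ((3-fluorophenyl)carbamoyl)amino, and a 4.7-fold lower number from compound 1 to compound 3 (0.67 log units; beyond the scatter) for the same group in place of ((4-chlorophenyl)carbamoyl)amino. Both steps are modest but beyond the scatter. Nothing available explains this gain. Each step shortens the group and changes its ring substituent together, so the compounds shown cannot separate these two changes. Also open, going by these compounds, is what a plain phenyl or 4-methoxyphenyl on this nitrogen would give.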